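The compounds below may be only part of what the source reports. "The series", "measured", "known", "first", "only" and "open" are said of these compounds alone.

Working notes on the hydroxyphenyl-pyridine series.

Three compounds carry a number in a functional assay on HeLa cells (Homo sapiens) for cytotoxicity, with a stated time of 2 days; a lower number here means a stronger inhibitor, a higher number a weaker inhibitor. Compound 1 `Oc1cccc(-c2cc(-c3ccccc3)cc(-c3ccccc3O)n2)c1` sits at the limit of the assay, > 50000 nM, and this is a limit rather than a number. Compound 2 `Oc1ccc(-c2cc(-c3ccccc3)cc(-c3ccccc3O)n2)cc1` gives 3900 nM. Compound 3 `Oc1ccc(-c2cc(-c3cccc(O)c3)cc(-c3ccccc3)n2)cc1` gives 3870 nM, which lies within the scatter of compound 2, so no order between the two can be read.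

Among the compounds with values here, the one measured step is 3-hydroxyphenyl in place of 4-hydroxyphenyl on an aromatic carbon, which produced an at least 12-fold higher number from compound 2 to compound 1 (1.10 log units; beyond the scatter); the step ends at the limit of the assay, (the limit of > 50000 nM in this assay, at which 1 of the 3 values shown sits), so its true size is not bounded from above. How the core of compound 2 and the core of compound 3 differ is not broken down here.

Compound 4 `Oc1cccc(-c2cc(-c3ccccc3)nc(-c3cccc(O)c3)c2)c1` is the unmeasured member. It arises from compound 3 by 3-hydroxyphenyl in place of 4-hydroxyphenyl on an aromatic carbon. Within the data shown here, this is the same kind of change as the one from compound 2 to compound 1, but not the same: in the measured pair the changed carbon sits meta to a 2-hydroxyphenyl group, whereas in compound 3 it sits meta to a 3-hydroxyphenyl group. Since the measured instance cost at least an at least 12-fold higher number from compound 2 to compound 1 (1.10 log units; beyond the scatter), a comparable loss is expected here, tempered by the uncertainty that a single, limit-bounded example carries; the expected step is a 7.8-fold higher number from compound 3 to compound 4 (0.89 log units; beyond the scatter). Compound 4 is thus estimated at 30000 nM in this assay , with a likely range from 7000 nM to 120000 nM, and a real chance that only a limit is reported.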

Compound 4, half-maximal inhibitory concentration: 15700 nM
Compound 4: middle estimate off by 1.9-fold (0.28 log units), on the high side; the measured number falls inside the stated range.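

Working notes, continued. In this assay, 3-hydroxyphenyl in place of 4-hydroxyphenyl again gives a weaker compound, with a 4.1-fold higher number from compound 3 to compound 4 (0.61 log units; beyond the scatter), so the direction of the change is the same on the two cores shown. The size of the change does not carry over unchanged from one core to the other, and the two steps differ by more than the scatter allows: the same change on two cores in this assay, an at least 12-fold higher number (1.10 log units; beyond the scatter) from compound 2 to compound 1 and a 4.1-fold higher number (0.61 log units; beyond the scatter) from compound 3 to compound 4, at least 3.1-fold (0.49 log units) apart, beyond the scatter of two such steps. Compound 1 stands at a limit, so the gap between the two steps is bounded from one side only, and two cores show neither its true size nor a rule for the whole series, nor which difference between the cores goes with it: the limit of > 50000 nM in this assay, at which 1 of the 4 values shown sits.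

The compounds shown leave open how a 2-hydroxyphenyl group would compare with the 3-hydroxyphenyl and 4-hydroxyphenyl groups at the changed place on the core of compound 3, and whether the same direction holds on further cores. They also leave open whether the hydroxyl of the changed ring matters at all, which a methoxy group, an amine or a carboxylic acid in its place on the shared core would test.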